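Removing the nitro group from a pyridyl thiosemicarbazone

The compounds below may be only part of what the source reports. "The series", "measured", "known", "first", "only" and "open" are said of these compounds alone.

Measured compounds:
compound 1, `C/C(=N\NC(=S)Nc1cccc([N+](=O)[O-])c1)c1ccccn1`, 140 nM
compound 2, `C/C(=N/NC(=S)Nc1cccc([N+](=O)[O-])c1)c1ccccn1`, 140 nM
compound 3, `CC(=NNC(=S)Nc1ccc(F)cc1)c1ccccn1`, 17 nM

In a functional assay on T98G cells (Homo sapiens) for cytotoxicity, read by MTT assay, with a stated time of 48 h (a higher number here means a weaker inhibitor, a lower number a stronger inhibitor), compound 1 gives 140 nM, level with compound 2 and together with it the highest of the three numbers; compound 3 sits below them both, and that gap lies beyond the scatter. Among the compounds with values here, the only measured step that changes one thing at a time is no change at the digits printed from compound 1 to compound 2 (within the scatter), which rests on the fact that compounds 1 and 2 differ only in the configuration as drawn and therefore says nothing about substituents on the aromatic ring.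

Compound 4, `C/C(=N\NC(=S)Nc1ccccc1)c1ccccn1`, differs from compound 1 as follows: hydrogen in place of nitro on an aromatic carbon. Within the data shown here, no measured step removes or replaces this group, so there is no direct precedent for the size of the change. What the numbers do show is that compound 3, which carries a different substituent on that ring, gives 17 nM, so a ring without the nitro group need not be weaker than compound 1.

Compound 4 is therefore expected to give 60 nM in this assay, with a plausible range from 15 nM to 250 nM. The step of a 2.3-fold lower number from compound 1 to compound 4 (0.37 log units; beyond the scatter) that this estimate implies is itself uncertain, and either a slight gain or no change beyond the scatter would fit what is known.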

Compound 4, half-maximal inhibitory concentration: 6.81 nM
For compound 4 the middle estimate is 8.8-fold (0.95 log units) above the measured one; measured number below the stated range.
By their numbers in this assay, from the lowest: compound 4; then compound 3; then compounds 1 and 2 (each within the scatter of the next).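

In this assay, within the data shown here, hydrogen in place of nitro on an aromatic carbon gives a 21-fold lower number from compound 1 to compound 4 (1.31 log units; beyond the scatter) and this large step is the first direct reading of the nitro group at this place on the ring. It shows that, on the core of compound 1, the nitro group is not needed for activity in this assay, and that the unsubstituted ring of compound 4 is clearly favoured over the nitro-bearing ring of compound 1. Among these compounds, compounds 1 and 4 are drawn with the same double-bond configuration, so the step rests on the ring substituent alone, and the configuration as drawn gave no separation in the one pair that tests it: the fact that compounds 1 and 2 differ only in the configuration as drawn.

Going by these compounds, whether any group at this place would cost activity, or only nitro does, stays open, since a single replacement by hydrogen cannot tell, and an amine or a methoxy group on the same aromatic carbon could fall near either compound 1 or compound 4. Also open, on these data alone, is whether the partner of compound 4 with the double bond drawn the other way would stay level with it, as compounds 1 and 2 stay level with each other.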